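Solubility notes on one change across two related cores

The compounds below may be only part of what the source reports. "The series", "measured", "known", "first", "only" and "open" are said of these compounds alone.

Compound 1 `COc1ccc(C2=[N+]3C(=Nc4c(-c5ccccc5)c5c(n4[B-]3(F)F)-c3ccc(OCC(=O)O)cc3CC5)C(c3ccccc3)=C2I)cc1` and compound 2 `COc1ccc(C2=[N+]3C(=Nc4c(-c5ccccc5)c5c(n4[B-]3(F)F)-c3ccc(OCC(=O)N[C@@H](CC(=O)O)C(=O)O)cc3CC5)C(c3ccccc3)=C2I)cc1` share one core; compound 3 `COc1ccc2c(c1)CCc1c(-c3ccccc3)c3n(c1-2)[B-](F)(F)[N+]1=C(c2ccc(OCC(=O)O)cc2)C(I)=C(c2ccccc2)C1=N3` and the not yet measured compound 4 `COc1ccc2c(c1)CCc1c(-c3ccccc3)c3n(c1-2)[B-](F)(F)[N+]1=C(c2ccc(OCC(=O)N[C@@H](CC(=O)O)C(=O)O)cc2)C(I)=C(c2ccccc2)C1=N3` share another. Compound 1 and compound 3 are built from the same atoms joined differently, and the difference between the two cores is not broken down here.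

In a physicochemical assay for solubility, in phosphate buffer (on this read-out higher numbers stand for higher solubility and lower numbers for lower solubility), compound 1 gives 28400 nM. In this assay compound 2 gives 165000 nM. The change between them is (1,2-dicarboxyethyl)amino in place of hydroxy on a carbonyl carbon, and it produced a 5.8-fold higher number from compound 1 to compound 2 (0.76 log units; beyond the scatter). In this assay compound 3 gives 21800 nM, the lowest of the three numbers; compound 3 and compound 1 lie within the scatter of each other, while compound 2 stands beyond the scatter from both.

Compound 4 differs from compound 3 by (1,2-dicarboxyethyl)amino in place of hydroxy on a carbonyl carbon. The place is described in the same words as for the pair above, so this is treated as the same change, now on the second core. Within the data shown here, only one measured example of it exists, and the expectation rests entirely on the step of a 5.8-fold higher number from compound 1 to compound 2 (0.76 log units; beyond the scatter). Carried over to compound 3, the expected step is a 5.8-fold higher number from compound 3 to compound 4 (0.76 log units; beyond the scatter). Compound 4 is therefore estimated at 126000 nM in this assay, with an expected range from 50000 nM to 320000 nM; the range is wide since the change has been seen once only and on a different core.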

Compound 4, solubility: 115000 nM
The estimate for compound 4 lay 1.1-fold (0.04 log units) above the measured number, and the stated range covers the measured number.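

In this assay, (1,2-dicarboxyethyl)amino in place of hydroxy on a carbonyl carbon gives (a 5.3-fold higher number from compound 3 to compound 4 (0.72 log units; beyond the scatter)), close in size to the step on the other core (a 5.8-fold higher number from compound 1 to compound 2 (0.76 log units; beyond the scatter)), so the change runs the same way on both cores and both steps lie beyond the scatter. This is one matched pair on each of two cores that are built from the same atoms joined differently, so it supports carrying the change between these two cores only and says nothing of any further core, nor which part of the entering group accounts for the step. No measurement is available here that bears on why the step occurs or why it recurs on the second core.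

The compounds shown leave open how much of the step depends on the whole (1,2-dicarboxyethyl)amino group, since a (carboxymethyl)amino group, with a single carboxylic acid, or a plain methylamino group on the same carbonyl carbon would separate the amide from the acids. Also open, from the compounds shown here alone, is whether a longer chain, such as (1,3-dicarboxypropyl)amino, or the opposite stereocentre would give a step of the same size on either core.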